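The compounds below may be only part of what the source reports. "The series", "measured", "known", "first", "only" and "open" are said of these compounds alone.

Compound 1 `O=c1cc(-c2ccccc2)oc2cc(N3COc4ccccc4C3)ccc12` gives no number in a functional assay on MCF7 cells (Homo sapiens) for inhibition, read by MTT assay, with a stated time of 48 h; on this read-out higher numbers stand for weaker inhibition and lower numbers for stronger inhibition; it is recorded only as "not active" (no number reported). Two related compounds do give numbers: compound 2 `O=c1cc(-c2ccccc2)oc2ccc(N3COc4c(cccc4[N+](=O)[O-])C3)cc12` gives 28400 nM in this assay, and compound 3 `COc1cc2c(c(OC)c1)OCN(c1ccc3c(=O)cc(-c4ccccc4)oc3c1)C2` gives 12100 nM. Compound 4 `O=c1cc(-c2ccccc2)oc2cc(N3COc4c(cccc4[N+](=O)[O-])C3)ccc12` differs from compound 1 by nitro in place of hydrogen on an aromatic carbon. Compound 2 also carries a nitro group and yields a measurable value, so a modest gain in inhibition in this assay is expected from compound 1 to compound 4, although compound 1 gives no number from which the size of that step can be drawn. Compound 4 is expected to come in near 30000 nM, within a range from 10000 nM to 100000 nM, with a real chance that only a limit is reported.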

Compound 4, half-maximal inhibitory concentration: "not active" (no number reported)
Compound 4 has no reported number here; there is nothing to compare the estimate with.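

For the compounds shown here, compound 1 and compound 4 both lack a number in this assay, and no step between them can be read. The compounds shown leave open whether nitro in place of hydrogen changes inhibition at all, and nothing measured here bears on this result.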